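The compounds below may be only part of what the source reports. "The series", "measured", "known", "first", "only" and "open" are said of these compounds alone.

Measured compounds:
compound 1 `COc1cc(C)cc(-c2nn(CC#N)cc2-c2ccc(-c3cccc(C(C)=O)c3)nc2)c1`, -17%
compound 2 `Cc1cc(O)cc(-c2nn(CC#N)cc2-c2ccnc(-c3ccc(Oc4ccccc4)cc3)c2)c1`, -94%

For the measured compounds named here, compound 2 stands lowest of the two numbers in a functional assay on HCC 2998 cells (Homo sapiens) for cytotoxicity, read by sulforhodamine B assay, with a stated time of 48 h, tested at 1 uM; on this read-out lower numbers stand for a stronger effect and higher numbers for a weaker effect at the one concentration tested; compound 1 sits higher, beyond the scatter, and the two differ in several places, so no single step is read from them. Compound 3 `Cc1cc(O)cc(-c2nn(CC#N)cc2-c2ccnc(-c3ccc(N(C)C)cc3)c2)c1` differs from compound 2 in one place: dimethylamino in place of phenoxy on an aromatic carbon. Going by the values given here, no measured pair isolates this change, so the step in this assay for compound 3 is expected to be toward higher numbers, of modest size, with a real chance of no change beyond the scatter. The estimate for compound 3 is -65% (-100% to -10%), an expected step of a number 29 percentage points higher from compound 2 to compound 3 (beyond the scatter).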

Compound 3, a percentage reported as activity, at one concentration (the size of the read-out at that concentration, not a potency): 13%
For compound 3 the middle estimate is 78 percentage points below the measured one; the whole stated range lies below it.
By their numbers in this assay, from the lowest: compound 2; then compound 1; then compound 3.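

Putting dimethylamino in place of phenoxy on this aromatic carbon, para to a large group, gives a number 107 percentage points higher from compound 2 to compound 3 (beyond the scatter) in this assay. This is the first single change shown, and it reveals that the read-out depends strongly on the group at this position: the strong effect of compound 2 is lost in compound 3 . Nothing available explains the size of this step.

As far as these compounds go, it remains open whether the oxygen or the aromatic ring of phenoxy matters more. A methoxy or an anilino group at this position would bear on that.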